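The source may hold more compounds than are shown below. What is called first, only, known or untested is meant among the compounds shown, and "the series" means these compounds.

Measured so far:
compound 1 `COCC(C(=O)N1CCN(c2cccc(C(F)(F)F)c2)CC1)N1C(=O)CCC1=O` gives 50%
compound 2 `CC(C(=O)N1CCN(c2ccccc2C(F)(F)F)CC1)N1C(=O)CCC1=O` gives 0%

Compound 1 stands highest of the two numbers in a functional assay on the whole organism (strain Swiss) with Mus musculus as the target, with a stated time of 2 h, at a dose of 100 mg/kg; on this read-out lower numbers stand for a weaker effect and higher numbers for a stronger effect at the one dose given; its nearest neighbour, compound 2, sits a long way lower, beyond the scatter. Going by the values given here, no step between the two is on hand, and since they differ in more than one place, their two values show only that gap and nothing about which change drives it.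

Compound 3 `CCC(C(=O)N1CCN(c2cccc(C(F)(F)F)c2)CC1)N1C(=O)CCC1=O` is still to be measured in this assay. Set against compound 1 it shows (methyl in place of methoxy on a saturated chain carbon, two bonds along the chain from an amide-type nitrogen in a ring and a carbonyl carbon). Among the compounds with values here, no measured step of this kind exists, so the size of the move has to be guessed; the expected step is a number 15 percentage points lower from compound 1 to compound 3 (beyond the scatter), a fall that may reach beyond the scatter but could also stay within it. Compound 3 is therefore expected to give 35% in this assay, with an estimated range from 0% to 70%.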

Compound 3, a percentage reported as activity, at one dose (the size of the read-out at that dose, not a potency): 25%
For compound 3 the middle estimate is 10 percentage points above the measured one; the range from low to high includes it.
By their numbers in this assay, from the lowest: compound 2; then compound 3; then compound 1.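

Going by these compounds alone, the first comparison in one place within this assay gives a number 25 percentage points lower from compound 1 to compound 3 (beyond the scatter) when methyl replaces methoxy on a saturated chain carbon, two bonds along the chain from an amide-type nitrogen in a ring and a carbonyl carbon. This position therefore influences the read-out: the methoxymethyl chain of compound 1 stands higher than the ethyl chain of compound 3, although the effect does not vanish with ethyl. Nothing on hand explains this step.

From the compounds shown here alone, whether a longer chain such as propyl, a hydroxymethyl group or an aminomethyl group at this position would raise or lower the number remains open. With a single dose and time, the step shows only a weaker effect for compound 3 than for compound 1 at that dose and time, and leaves open how the two compare at any other dose or time.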